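Aryl Variation on the Shared Core: Outlook for Compound 3

The compounds below may be only part of what the source reports. "The series", "measured", "known", "first", "only" and "open" are said of these compounds alone.

compound 1 `COc1ccc(-c2cn3ccnc3c(-c3ccc4ncn(C5CCCCC5)c4c3)n2)cc1` — -20.9%
compound 2 `Brc1ccc(-c2cn3ccnc3c(-c3ccc4ncn(C5CCCCC5)c4c3)n2)cc1` — 35.5%

In a functional assay on NCI-H522 cells (Homo sapiens) for inhibition, read by sulforhodamine B assay, with a stated time of 48 h, tested at 10 uM (a lower number here means less inhibition, a higher number more inhibition at the concentration tested (going by the name of the read-out)), compound 1 gives -20.9% while compound 2 gives 35.5%. Within the data shown here, compound 2 stands highest of the two numbers in this assay, with compound 1 as its only neighbour, and the single recorded step a number 56.4 percentage points higher from compound 1 to compound 2 (beyond the scatter) shows that the group on this ring moves the read-out far beyond the scatter.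

Compound 3 `FC(F)(F)c1cccc(-c2cn3ccnc3c(-c3ccc4ncn(C5CCCCC5)c4c3)n2)c1` has not been measured. Its change from compound 2 is 3-(trifluoromethyl)phenyl in place of 4-bromophenyl on an aromatic carbon. Among the measured compounds shown here, no measured step exchanges one such aryl group for another of this kind; the one step available, a number 56.4 percentage points higher from compound 1 to compound 2 (beyond the scatter), only shows the read-out is sensitive here. Since the bromo that accompanied the higher number leaves, a step downward in this assay is expected, of moderate size. For compound 3 the estimate is 18%, between -15% and 50%, expected as a step of a number 17.5 percentage points lower from compound 2 to compound 3 (beyond the scatter).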

Compound 3, a percentage reported as inhibition, at one concentration (the size of the read-out at that concentration, not a potency): 10.7%
Compound 3: middle estimate off by 7.3 percentage points, on the high side; measured number inside the range.
By their numbers in this assay, from the lowest: compound 1; then compound 3; then compound 2.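

In this assay, replacing 4-bromophenyl with 3-(trifluoromethyl)phenyl gives a number 24.8 percentage points lower from compound 2 to compound 3 (beyond the scatter), so this exchange lowers the read-out without returning it to the level of compound 1. Replacing 4-methoxyphenyl with 3-(trifluoromethyl)phenyl gives a number 31.6 percentage points higher from compound 1 to compound 3 (beyond the scatter), which places compound 3 between the two earlier compounds and shows that a positive inhibition reading at this position does not depend on the bromine. No measurement on hand accounts for either step.

Compound 3 differs from compound 2 in both the substituent and its place on the phenyl ring, so the compounds shown cannot separate these two contributions. Going by these compounds, how an amine or a carboxylic acid on this aryl ring would read in this assay also remains open.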